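The source may hold more compounds than are shown below. What is called first, only, known or untested is meant among the compounds shown, and "the series" means these compounds.

In a physicochemical assay for lipophilicity, read by HPLC (on this read-out higher numbers stand for higher lipophilicity and lower numbers for lower lipophilicity), compound 1 (`COC(=O)C1(c2ccc(NC(=O)Nc3cccnc3Oc3ccccc3C(C)(C)C)cc2)CC1`) gives 5.1, the second highest of three numbers. Compound 3 (`CN(C)Cc1cccc(-c2ccc(NC(=O)Nc3cccnc3Oc3ccccc3C(C)(C)C)c(F)c2)c1`) gives 5.5, and compound 2 (`CN(C)Cc1ccc(NC(=O)Nc2cccnc2Oc2ccccc2C(C)(C)C)c(F)c1`) gives 4.2; both gaps to compound 1 lie beyond the scatter.

Compound 4 (`CN(C)CC(C)(C)COc1ccc(NC(=O)Nc2cccnc2Oc2ccccc2C(C)(C)C)cc1`) is still unmeasured. The change from compound 1 is 2-((dimethylamino)methyl)-2-methylpropoxy in place of 1-(methoxycarbonyl)cyclopropyl on an aromatic carbon. Going by the values given here, no measured step makes this exchange.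

The nearest evidence is a number 1.30 log units higher from compound 2 to compound 3 (beyond the scatter), a large step beyond the scatter, with 3-((dimethylamino)methyl)phenyl in place of (dimethylamino)methyl on an aromatic carbon. The entering 2-((dimethylamino)methyl)-2-methylpropoxy also carries the dimethylamino end, and the two compounds with that end fall on either side of compound 1. A position for compound 4 inside that span is therefore expected, with compound 2 at 4.2 on one side and compound 3 at 5.5 on the other.

In this assay, a small downward move that stays within the scatter is expected, a number 0.20 log units lower from compound 1 to compound 4 (within the scatter). For compound 4 the estimated value is 4.9, with an expected range from 4.3 to 5.5.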

Compound 4, partition coefficient: 5.1
Compound 4: the middle estimate sits 0.20 log units below what was measured, within the range that was stated.
By their numbers in this assay, from the lowest: compound 2; then compounds 1 and 4 (each within the scatter of the next); then compound 3.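

In this assay, the exchange gives no change at the digits printed from compound 1 to compound 4 (within the scatter), on an aromatic carbon para to a large group. At this position, therefore, 1-(methoxycarbonyl)cyclopropyl, with its three-membered ring and 7 heavy atoms, and 2-((dimethylamino)methyl)-2-methylpropoxy, with no ring, 9 heavy atoms and a nitrogen, are not separated on this read-out, even though the two groups share little beyond their hydrogen-bond counts. No supporting measurement is available to explain this result.

Open, going by these compounds, is whether that equivalence extends to other groups at this position, such as a carboxylic acid in place of the methyl ester or a primary amine in place of the dimethylamino end. On these data alone, the separate contributions of the ether oxygen, the two branching methyl groups and the chain length also remain open, as does the outcome with a longer chain.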